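The source may hold more compounds than are shown below. What is called first, only, known or untested is meant among the compounds shown, and "the series" means these compounds.

Measured so far in an ADME assay on Vero 76 cells (Chlorocebus sabaeus) for cytotoxicity, read by MTT assay, with a stated time of 96 h; a lower number here means that less compound is tolerated, a higher number that more compound is tolerated:
compound 1, `Brc1ccc(NCc2cn(-c3ccccc3)nc2-c2ccccc2)cc1`: 52000 nM
compound 2, `Cc1ccc(-c2nn(-c3ccccc3)cc2CNc2ccc(Br)cc2)cc1`: 92000 nM
compound 3, `Cc1ccc(NCc2cn(-c3ccccc3)nc2-c2ccc(Br)cc2)cc1`: the assay reports only a limit for compound 3, > 100000 nM.

Between compound 2 and compound 1 the change is hydrogen in place of methyl on an aromatic carbon, and the step is a 1.8-fold lower number from compound 2 to compound 1 (0.25 log units; within the scatter). Compound 3 and compound 2 are built from the same atoms joined differently; the difference between the two cores is not broken down here. Compound 4, `Brc1ccc(-c2nn(-c3ccccc3)cc2CNc2ccccc2)cc1`, differs from compound 3 by hydrogen in place of methyl on an aromatic carbon, the same change at the same kind of place. In this assay the step from compound 3 to compound 4 is expected to be a number no higher from compound 3 to compound 4 (the limit leaves the size open). That expectation rests on a 1.8-fold lower number from compound 2 to compound 1 (0.25 log units; within the scatter). For compound 3 the value sits at the limit, (the limit of > 100000 nM in this assay, at which 1 of the 3 values shown sits). Compound 4 is therefore estimated at 100000 nM, with a range of 50000 nM to 200000 nM, and it may again come back as a limit only.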

Compound 4, half-maximal cytotoxic concentration: 52000 nM
Compound 4: middle estimate off by 1.9-fold (0.28 log units), on the high side; low and high end bracket the measured number.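

In this assay, hydrogen in place of methyl on an aromatic carbon gives an at least 1.9-fold lower number from compound 3 to compound 4 (0.28 log units; that floor lies within the scatter), which can be set beside the same change on the other core: the same change on two cores in this assay, a 1.8-fold lower number (0.25 log units; within the scatter) from compound 2 to compound 1 and an at least 1.9-fold lower number (0.28 log units; that floor lies within the scatter) from compound 3 to compound 4; the limit leaves it open whether they differ

Compound 3 has only a limit in this assay, > 100000 nM. The two cores therefore show no conflict, but neither printed figure lies beyond the scatter, and nothing shows that the change has the same size on both cores.

Open, going by these compounds, is how other groups in place of that methyl would read in this assay, for instance an amine, a carboxylic acid or a longer chain. Also open, on these data alone, is whether any such group would separate the two cores.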